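The source may hold more compounds than are shown below. What is called first, only, known or untested is meant among the compounds shown, and "the series" means these compounds.

Working notes on the series. Compound 1 `C=C1[C@@H](OC(C)=O)C[C@@H]2[C@](C)(COC=O)[C@H](OC(C)=O)CC[C@@]2(C)[C@@H]1C[C@@H](Nc1cccc2ccccc12)C1=CCOC1=O` is the point of departure; in a functional assay on A549 cells (Homo sapiens) for cytotoxicity, read by sulforhodamine B assay (on this read-out higher numbers stand for weaker inhibition and lower numbers for stronger inhibition), compound 1 gives 35600 nM, the highest of the three numbers obtained so far. Compound 2 `C=C1[C@@H](OC(C)=O)C[C@@H]2[C@](C)(CO[Si](C)(C)C(C)(C)C)[C@H](OC(C)=O)CC[C@@]2(C)[C@@H]1C[C@@H](Nc1cccc2ccccc12)C1=CCOC1=O` keeps the core of compound 1 and changes only the substituent on the oxygen on a saturated carbon; in this assay compound 2 gives 4970 nM, and the step is a 7.2-fold lower number from compound 1 to compound 2 (0.86 log units; beyond the scatter). Compound 3 `C=C1[C@@H](OC(C)=O)C[C@@H]2[C@](C)(CO[Si](C)(C)C(C)(C)C)[C@H](OC(C)=O)CC[C@@]2(C)[C@@H]1C/C=C1/C(=O)OC[C@H]1OC(C)=O` carries the same silyl ether as compound 2 but differs from it at the other end of the molecule; compound 3 gives 4640 nM. The numbers for compound 2 and compound 3 lie within the scatter of each other, so no order between them can be read.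

Compound 4 `C=C1[C@@H](OC(C)=O)C[C@@H]2[C@](C)(COC=O)[C@H](OC(C)=O)CC[C@@]2(C)[C@@H]1C[C@@H](Nc1ccc(F)cc1)C1=CCOC1=O` differs from compound 1 by 4-fluorophenyl in place of naphthalen-1-yl on an amine nitrogen. Within the data shown here, no measured step touches this aryl group on the amine nitrogen: the only single-point step in hand, the one from compound 1 to compound 2, concerns the oxygen on a saturated carbon and leaves the amine untouched, and the pair of compound 2 and compound 3 changes a different region altogether. With nothing to anchor a shift, the expectation for compound 4 is a step of a 1.0-fold lower number from compound 1 to compound 4 (0.01 log units; within the scatter), that is no change beyond the scatter. Compound 4 is therefore estimated at 35000 nM, with a range from 12000 nM to 100000 nM.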

Compound 4, half-maximal inhibitory concentration: 21300 nM
Compound 4: the middle estimate sits 1.6-fold (0.22 log units) above what was measured, within the range that was stated.
By their numbers in this assay, from the lowest: compounds 3 and 2 (each within the scatter of the next); then compounds 4 and 1 (each within the scatter of the next).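

Among these compounds, the first reading at the amine nitrogen in this assay is a 1.7-fold lower number from compound 1 to compound 4 (0.22 log units; within the scatter), so 4-fluorophenyl in place of naphthalen-1-yl, one aromatic ring in place of two, gives no order between these two compounds. The second ring of naphthalen-1-yl and the fluorine therefore cannot be separated here, since the two groups differ in both features and only their combined swap is read. The only other single-place step, a 7.2-fold lower number from compound 1 to compound 2 (0.86 log units; beyond the scatter), lies beyond the scatter and concerns the oxygen on a saturated carbon, so among the compounds shown, only that change has a readable effect on this read-out, and nothing on hand bears on why this aryl swap gives no readable step.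

Whether a step beyond the scatter can arise on the amine nitrogen remains open, as the compounds shown include neither a non-aromatic group such as cyclohexyl nor a benzyl group in that place. Also open, from the compounds shown here alone, is whether 4-fluorophenyl behaves as naphthalen-1-yl does when the tert-butyldimethylsilyl ether of compound 2 is present.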